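This account rests on a few compounds, and the source may have more. Where it says the series, first, only, none or still open, it means among the compounds named here.

The measured compounds:
Compound 1, `CNC(=O)/C=C1\CCc2c(F)cc(F)cc21`, gives 100% in a functional assay on the whole organism with Mus musculus as the target, at a dose of 100 mg/kg by the intraperitoneal route; on this read-out higher numbers stand for more inhibition at the one dose given (going by the name of the read-out) and lower numbers for less inhibition.
Compound 2, `CNC(=O)/C=C1\CCc2ccc(Cl)cc21`, gives 16% in this assay.
Compound 3, `O=C(/C=C1\CCc2c(F)cc(F)cc21)NC1CC1`, gives 100% in this assay.

Compound 1 and compound 3 share a core and differ in one change, (cyclopropyl in place of methyl on an amide-type nitrogen); that step is no change at the digits printed from compound 1 to compound 3 (within the scatter). Compound 2 has a different core; the difference between the two cores is not broken down here. Compound 2 stands lowest of the three. Compound 4, `O=C(/C=C1\CCc2ccc(Cl)cc21)NC1CC1`, is not yet measured. From compound 2 to compound 4 the change is cyclopropyl in place of methyl on an amide-type nitrogen, the same change made from compound 1 to compound 3, at the same place. That earlier step showed no change, but both numbers sit at the top of the scale, so it says little about a low starting point. The step from compound 2 to compound 4 is expected to be a number 9 percentage points higher from compound 2 to compound 4 (within the scatter), resting on no change at the digits printed from compound 1 to compound 3 (within the scatter). Compound 4 is therefore estimated at 25%, between 5% and 60%.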

Compound 4, a percentage reported as inhibition, in the whole organism at one dose (the size of the read-out at that dose, not a potency): 50%
Estimate against measurement, compound 4: 25 percentage points below, and the stated range covers the measured number.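

Carrying the swap of methyl for cyclopropyl on an amide-type nitrogen from one core to another did not give the same step in this assay: the same change on two cores in this assay, no change at the digits printed (within the scatter) from compound 1 to compound 3 and a number 34 percentage points higher (beyond the scatter) from compound 2 to compound 4, 34 percentage points apart, beyond the scatter of two such steps

On the core of compound 2, the swap gives a number 34 percentage points higher from compound 2 to compound 4 (beyond the scatter). This does not show that the two cores truly respond differently: compound 1 gives 100% and compound 3 gives 100%, at the top of the scale, where any further rise would stay hidden.

The compounds shown leave open how other groups on that nitrogen, such as ethyl, isopropyl or cyclobutyl, would compare with cyclopropyl on the core of compound 2. They also leave open whether a longer chain there would fare any differently.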